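The source may report more compounds than this note shows. Statements on the series, on what has been measured and on what is new or still open speak of the compounds shown alone.

Measured in a functional assay on MCF7 cells (Homo sapiens) for antiproliferative activity, with a stated time of 5 days; a higher number here means a weaker inhibitor, a lower number a stronger inhibitor:
- compound 1 `CCCCc1ccc2[nH]c(-c3ccc(OC)cc3)c(/C=N/NC(=O)c3ccccc3)c2c1`: 130 nM
- compound 2 `CCCCc1ccc2[nH]c(-c3ccc(OC)cc3)c(/C=N/NC(=O)c3cccc(O)c3)c2c1`: "not determined" (no result reported)

For the measured compounds named here, compound 2 has no number in this assay, so it cannot be placed on the scale, and no step can be measured from it. The only measured reference in this series is compound 1, at 130 nM.

The next structure is compound 3 `CCCCc1ccc2[nH]c(-c3ccc(OC)cc3)c(/C=N/NC(=O)c3ccccn3)c2c1`. The change is pyridin-2-yl in place of 3-hydroxyphenyl on a carbonyl carbon, which in words is pyridin-2-yl in place of 3-hydroxyphenyl on a carbonyl carbon. The shared core and its other groups stay as they are.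

Going by the values given here, no measured step in this assay shows the effect of such a change, so the data give no direction for it. The expectation therefore rests on compound 1 at 130 nM, and it is a value within the usual scatter of that level, though with wide uncertainty.

For compound 3 the estimated value is 150 nM, with an expected range of 50 nM to 450 nM.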

Compound 3, half-maximal inhibitory concentration: 160 nM
Compound 3: middle estimate off by 1.1-fold (0.03 log units), on the low side, and the stated range covers the measured number.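

In this assay, the position on the carbonyl carbon now has its first readable step: pyridin-2-yl in place of phenyl gives a 1.2-fold higher number from compound 1 to compound 3 (0.09 log units; within the scatter), so this exchange of a carbon-only ring for a ring with one hetero atom leaves the two compounds indistinguishable in this assay. Compound 2 has no number, so the steps involving it cannot be read, and the result says nothing about the 3-hydroxyphenyl group. No evidence beyond the values themselves bears on this result.

The compounds shown leave open what pyridin-3-yl, an aminophenyl group or a saturated ring such as cyclohexyl would give on the same carbonyl carbon. They also leave open how a carboxylic acid on that aromatic ring would compare with compound 1 and compound 3.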